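A few compounds are considered here, and "the series" means these few. Any claim that something is new, unique, unknown or untested is made for them only; others in the source may bear on it.

Working notes on the series, values from a functional assay on A549 cells (Homo sapiens) for antiproliferative activity, read by sulforhodamine B assay, with a stated time of 72 h; a lower number here means a stronger inhibitor, a higher number a weaker inhibitor

- compound 1 `CC(=O)Oc1cc2c(CCC=C(C)C)c(C)ccc2cc1C(C)C`: 25500 nM
- compound 2 `CC(=O)Oc1cc2c(CC[C@H](O)C(C)(C)O)c(C)ccc2cc1C(C)C`: 50500 nM

Only these two measurements exist so far, and compound 2 cannot be told apart from compound 1 on the numbers. Among the compounds with values here, the single measured step is a 2.0-fold higher number from compound 1 to compound 2 (0.30 log units; within the scatter). In that step, 1,2-dihydroxy-2-methylpropyl takes the place of 2-methylprop-1-en-1-yl on a saturated chain carbon.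

Next comes compound 3 `CC(=O)Oc1cc2c(CC[C@@H](O)C(C)(C)O)c(C)ccc2cc1C(C)C`, set against compound 2: the two compounds have the same atoms and bonds and differ only in configuration as drawn: 1 of 1 stereo elements differ; a stereocentre at a saturated chain carbon is drawn S in compound 2 and R in compound 3. Within the data shown here, no measured pair isolates a change of configuration, so the data give no direct precedent. The step of a 2.0-fold higher number from compound 1 to compound 2 (0.30 log units; within the scatter) bears on the question only indirectly, as it concerns the substituent that carries this stereocentre and stayed within the scatter. No step beyond the scatter is therefore expected in this assay, and no direction can be favoured. The estimate stays anchored on compound 2 at 50500 nM, with a wide range.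

The estimated change is a 1.1-fold lower number from compound 2 to compound 3 (0.05 log units; within the scatter).

For compound 3 the expected value is 45000 nM, with an estimated range from 20000 nM to 100000 nM.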

Compound 3, half-maximal inhibitory concentration: 48600 nM
The estimate for compound 3 lay 1.1-fold (0.03 log units) below the measured number; the measured number falls inside the stated range.
By their numbers in this assay, from the lowest: compounds 1, 3 and 2 (each within the scatter of the next).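

In this assay, within the data shown here, the change of the stereocentre at a saturated chain carbon from S to R gives a 1.0-fold lower number from compound 2 to compound 3 (0.02 log units; within the scatter), the only direct reading of configuration so far, and the two drawn forms cannot be told apart on the numbers. This step can be read as one of configuration alone on the strength of a single feature of the pair: the fact that compounds 2 and 3 differ only in the configuration as drawn. The replacement of 2-methylprop-1-en-1-yl by 1,2-dihydroxy-2-methylpropyl now has a second reading, with the opposite configuration, in a 1.9-fold higher number from compound 1 to compound 3 (0.28 log units; within the scatter), so with either drawn form this replacement stays within the scatter.

The compounds shown leave open whether a different group in place of 1,2-dihydroxy-2-methylpropyl, such as an amine, a carboxylic acid or a longer chain, would give a step beyond the scatter. Also open, on these data alone, is whether configuration at this carbon would make a readable difference with a group other than 1,2-dihydroxy-2-methylpropyl, for instance a single hydroxyl with an amine alongside it.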